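This account rests on a few compounds, and the source may have more. Where it says the series, first, only, none or still open, it means among the compounds named here.

Measured so far:
Compound 1, `CC(=O)O[C@@H]1OC(=O)[C@](C)(C(C)=O)[C@@H]1C`: in a functional assay on HT-29 cells (Homo sapiens) for cytotoxicity, read by MTT assay (a lower number here means a stronger inhibitor, a higher number a weaker inhibitor), compound 1 gives 5000 nM.
Compound 2, `CC(=O)O[C@@H]1OC(=O)[C@@](C(C)=O)(C2SCCCS2)[C@@H]1C`: in this assay compound 2 gives > 50000 nM, which is a limit of the assay rather than a number.

Compound 2 thus stands at the weak end of the numbers shown, sitting at the limit of > 50000 nM in this assay, at which 1 of the 2 values shown sits. The step followed here leads to compound 3, `CC(=O)O[C@@H]1OC(=O)[C@](O)(C(C)=O)[C@@H]1C`, which differs from compound 2 by one oxygen atom in place of a group of 6 heavy atoms (4 carbon, 2 sulfur; one six-membered non-aromatic ring with 2 hetero atoms), on a saturated ring carbon. Among the compounds with values here, the only measured step that bears on this position, an at least 10-fold higher number from compound 1 to compound 2 (1.00 log units; beyond the scatter), shows that attaching the six-membered ring with two sulfur atoms to that ring carbon pushed the number up well beyond the scatter. Taking that ring away again in favour of a small hydroxy group is expected to undo part of this, so the expected step of an at least 5.0-fold lower number from compound 2 to compound 3 (0.69 log units; beyond the scatter) points toward a lower number in this assay. Compound 3 is therefore expected to give about 10000 nM, with a likely range from 3000 nM to 50000 nM.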

Compound 3, half-maximal inhibitory concentration: > 50000 nM
Compound 3 ended at the assay's limit; the forecaster's own chance of this, stated with the estimate: 30%; middle value at least 5.0-fold (0.69 log units) from the limit.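

In this assay, hydroxy in place of methyl on this saturated ring carbon gives an at least 10-fold higher number from compound 1 to compound 3 (1.00 log units; beyond the scatter). A replacement of a single oxygen atom therefore moves the number past the scatter just as the much larger ring with two sulfur atoms did, so a large group is not needed for this change among the compounds shown. Compound 2 and compound 3 share one limit of the assay, so the step between them cannot be read and neither replacement can be ranked against the other: the limit of > 50000 nM in this assay, at which 2 of the 3 values shown sit.

Methyl is thus the only group here on this ring carbon with a readable number, and whether an ethyl group, a fluorine atom or an amine would also give one remains open. The compounds shown also cannot tell how far the activity falls with either replacement.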